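Urea aryl swap: weighing a nitro ring against chlorine

This account rests on a few compounds, and the source may have more. Where it says the series, first, only, none or still open, it means among the compounds named here.

Of the compounds shown here, three sharing one core have been measured so far. Compound 1 `COc1cc2ncnc(NCc3cccc(NC(=O)Nc4ccc(C)cc4)c3)c2cc1OC` gives 12900 nM in a functional assay on A549 cells (Homo sapiens) for antiproliferative activity, read by MTT assay; a lower number here means a stronger inhibitor, a higher number a weaker inhibitor. Compound 2 `COc1cc2ncnc(NCc3cccc(NC(=O)Nc4ccc(C(C)(C)C)cc4)c3)c2cc1OC` gives 5210 nM in this assay, and compound 3 `COc1cc2ncnc(NCc3cccc(NC(=O)Nc4ccccc4Cl)c3)c2cc1OC` gives 15200 nM in this assay. Compound 3 thus holds the highest number of the three, though the gap to compound 1 is small: a 1.2-fold higher number from compound 1 to compound 3 (0.07 log units; within the scatter). The gap to compound 2 is larger: a 2.9-fold higher number from compound 2 to compound 3 (0.47 log units; beyond the scatter).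

Compound 4 `COc1cc2ncnc(NCc3cccc(NC(=O)Nc4ccc([N+](=O)[O-])cc4)c3)c2cc1OC` is not yet measured. It differs from compound 3 in one place: 4-nitrophenyl in place of 2-chlorophenyl on an amide-type nitrogen. Among the compounds with values here, the steps that bear on this are those that change the same ring on the amide-type nitrogen. Moving from one aryl group to another there gave a 1.2-fold higher number from compound 1 to compound 3 (0.07 log units; within the scatter) and a 2.9-fold higher number from compound 2 to compound 3 (0.47 log units; beyond the scatter), while enlarging a substituent on that ring gave a 2.5-fold lower number from compound 1 to compound 2 (0.39 log units; beyond the scatter). Within the data shown here, every change at this position so far has moved the number by no more than a modest amount, and no measured compound carries a nitro group, so there is little basis for expecting a large shift.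

Compound 4 is therefore expected to land near compound 3, with a 1.3-fold lower number from compound 3 to compound 4 (0.10 log units; within the scatter), giving an estimated 12000 nM in this assay, within a range of 5000 nM to 30000 nM.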

Compound 4, half-maximal inhibitory concentration: > 50000 nM
Compound 4 gave a limit, no number; the forecaster's own chance of this, stated with the estimate: 5%; middle value at least 4.1-fold (0.61 log units) away from the limit.
By their numbers in this assay, from the lowest: compound 2; then compounds 1 and 3 (each within the scatter of the next). At a limit, above all of these: compound 4.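

Compound 4 gives only a limit in this assay, not a number: the limit of > 50000 nM in this assay, at which 1 of the 4 values shown sits. Within the data shown here, this position is therefore less forgiving than the earlier compounds suggested, since the swap of aryl groups produces an at least 3.2-fold higher number from compound 3 to compound 4 (0.51 log units; beyond the scatter), a step that reaches past every earlier change on this ring. Exchanging only the group on the aromatic carbon tells the same story: nitro in place of methyl gives an at least 3.8-fold higher number from compound 1 to compound 4 (0.58 log units; beyond the scatter), and nitro in place of tert-butyl gives an at least 9.5-fold higher number from compound 2 to compound 4 (0.98 log units; beyond the scatter), so what sits on that carbon can decide whether the compound registers a number at all in this assay.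

Among these compounds, since compound 4 is the only compound with a nitro group and its value is a limit, the true size of these steps stays unknown, and a single compound cannot show whether the loss belongs to nitro alone or extends to other groups. Going by these compounds, whether an amine, a nitrile or a methoxy group on that same aromatic carbon would stay close to compound 1 or rise as compound 4 does also remains open.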